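The compounds below may be only part of what the source reports. "The series", "measured", "known", "first", "only" and "open" are said of these compounds alone.

Three compounds have been measured in a functional assay on ECa-109 cells for inhibition, with ECa-109 cell line (Homo sapiens) as the target, read by sulforhodamine B assay; on this read-out higher numbers stand for weaker inhibition and lower numbers for stronger inhibition:

Compound 1 `O=C1C(Nc2ccc(I)cc2)=CC(=O)c2c1nc1n2[C@H]2OC[C@@H](O)[C@H]2OC1` gives 2530 nM
Compound 2 `O=C1C(Nc2ccccc2)=CC(=O)c2c1nc1n2[C@H]2OC[C@@H](O)[C@H]2OC1` gives 3560 nM
Compound 3 `O=C1C=C(Nc2ccccc2)C(=O)c2c1nc1n2[C@H]2OC[C@@H](O)[C@H]2OC1` gives 4970 nM

Compound 2 and compound 3 are built from the same atoms joined differently; the difference between the two cores is not broken down here. Compound 1 differs from compound 2 by iodo in place of hydrogen on an aromatic carbon, and this change gave a 1.4-fold lower number from compound 2 to compound 1 (0.15 log units; within the scatter). Compound 4 `O=C1C=C(Nc2ccc(I)cc2)C(=O)c2c1nc1n2[C@H]2OC[C@@H](O)[C@H]2OC1` is not yet measured; it differs from compound 3 by iodo in place of hydrogen on an aromatic carbon, the same change made on the other core. Because a 1.4-fold lower number from compound 2 to compound 1 (0.15 log units; within the scatter) was small, the step is expected to be small again, estimated as a 1.4-fold lower number from compound 3 to compound 4 (0.14 log units; within the scatter), starting from compound 3 at 4970 nM. Compound 4 is therefore expected to give about 3600 nM in this assay, most likely between 1600 nM and 8000 nM.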

Compound 4, half-maximal inhibitory concentration: 2300 nM
For compound 4 the middle estimate is 1.6-fold (0.19 log units) above the measured one, within the range that was stated.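

In this assay, iodo in place of hydrogen gave a 2.2-fold lower number from compound 3 to compound 4 (0.33 log units; beyond the scatter), a modest step towards stronger inhibition. Set beside the same change on the other core, the two steps cannot be told apart: the same change on two cores in this assay, a 1.4-fold lower number (0.15 log units; within the scatter) from compound 2 to compound 1 and a 2.2-fold lower number (0.33 log units; beyond the scatter) from compound 3 to compound 4, 1.5-fold (0.19 log units) apart, within the scatter of two such steps So, for these two pairs, the effect of the change on one core gave a fair guide to its effect on the other, but this does not show that the steps are truly equal, or that the change would carry to any further core.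

Going by these compounds, it remains open whether another group in the same place, such as chloro, an amine or a carboxylic acid, would also give similar steps on both cores.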